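The source may report more compounds than this note shows. Statements on the series, on what has been measured and on what is new or still open speak of the compounds shown alone.

Compound 1 `N#Cc1ccc(/C=N/NC(=O)Nc2cc3c(Nc4ccc(F)c(Cl)c4)ncnc3cc2O[C@H]2CCOC2)cc1`: 26400 nM
Compound 2 `O=C(N/N=C/c1ccc(O)cc1)Nc1cc2c(Nc3ccc(F)c(Cl)c3)ncnc2cc1O[C@H]1CCOC1`: 70 nM
Compound 3 `COc1cc2ncnc(Nc3ccc(F)c(Cl)c3)c2cc1NC(=O)N/N=C/c1ccc(C#N)cc1`: 34100 nM

These values come from a functional assay on HepG2 cells (Homo sapiens) for cytotoxicity, read by MTT assay, with a stated time of 72 h; a higher number here means a weaker inhibitor, a lower number a stronger inhibitor. Compound 3, at 34100 nM, sits at the high end of the numbers, which means weak inhibition. It is level with compound 1, since a 1.3-fold higher number from compound 1 to compound 3 (0.11 log units; within the scatter) is a swap of methyl for oxolan-3-yl on an oxygen on an aromatic ring. Compound 2 lies far lower, at 70 nM.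

The next compound is compound 4 `COc1cc2ncnc(Nc3ccc(F)c(Cl)c3)c2cc1NC(=O)N/N=C/c1ccc(O)c(Br)c1`, which differs from compound 3 as follows: 3-bromo-4-hydroxyphenyl in place of 4-cyanophenyl on a carbon with a double bond to nitrogen. In short, 3-bromo-4-hydroxyphenyl replaces 4-cyanophenyl on a carbon with a double bond to nitrogen.

Among the compounds with values here, the closest precedent is a 380-fold lower number from compound 1 to compound 2 (2.58 log units; beyond the scatter), a large step in which hydroxy replaces cyano on an aromatic carbon. Compound 4 makes a similar exchange on the methyl-bearing side of the series, and the methyl swap above changed nothing beyond the scatter. A similar large fall in this assay is therefore expected. However, no measured compound carries a bromo group, so the data do not show what it adds, and this one precedent is a single pair. The expected change is a 110-fold lower number from compound 3 to compound 4 (2.06 log units; beyond the scatter). For compound 4 the estimated value is 300 nM, with an expected range of 40 nM to 5000 nM.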

Compound 4, half-maximal inhibitory concentration: 23800 nM
Beside the measured number, compound 4's estimate is 79-fold (1.90 log units) below it; the whole stated range lies below it.
By their numbers in this assay, from the lowest: compound 2; then compounds 4, 1 and 3 (each within the scatter of the next).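

In this assay, putting 3-bromo-4-hydroxyphenyl in place of 4-cyanophenyl on the carbon with a double bond to nitrogen gives a 1.4-fold lower number from compound 3 to compound 4 (0.16 log units; within the scatter). This shows that losing the nitrile and gaining a hydroxy on that phenyl ring does not by itself guarantee a low number, even though the simpler hydroxy-for-cyano exchange on the compounds carrying oxolan-3-yl gave a 380-fold lower number from compound 1 to compound 2 (2.58 log units; beyond the scatter). Nothing offered here on how these compounds behave accounts for the contrast between the two exchanges.

Two things differ between those exchanges, the bromo group on the ring and the methyl in place of oxolan-3-yl on the oxygen, and the compounds shown cannot tell which of them matters, or whether it takes both together; a compound with methyl on that oxygen and a plain 4-hydroxyphenyl would pull them apart. Also open, as far as these compounds go, is whether the hydroxy itself is what counts in compound 2, or whether an amine or a carboxylic acid in its place on the phenyl ring would give a similarly low number.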